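Cytotoxicity working notes: aryl exchange on the shared core

This account rests on a few compounds, and the source may have more. Where it says the series, first, only, none or still open, it means among the compounds named here.

Measured so far:
compound 1 `Fc1ccc(Oc2ccc3c(NCCCNCc4ccco4)ccnc3c2)cc1` gives 16000 nM in an ADME assay on HepG2 cells (Homo sapiens) for cytotoxicity, read by luminescence, CellTiter-Glo and ATP content, with a stated time of 72 h; a higher number here means that more compound is needed for the effect, a lower number that less compound is needed
compound 2 `c1coc(CNCCCNc2ccnc3cc(CC4CCCCC4)ccc23)c1` gives 1700 nM in this assay

Compound 2 holds the lowest of the two numbers in this assay. Within the data shown here, the single measured step in the set is a 9.4-fold lower number from compound 1 to compound 2 (0.97 log units; beyond the scatter), which lies beyond the scatter.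

Compound 3 `c1coc(CNCCCNc2ccnc3cc(-c4cccc5ccccc45)ccc23)c1` differs from compound 2 by naphthalen-1-yl in place of cyclohexylmethyl on an aromatic carbon. Among the measured compounds shown here, no measured step covers an exchange of this kind; the one step of a 9.4-fold lower number from compound 1 to compound 2 (0.97 log units; beyond the scatter) touches the same position and shows that what sits there can move the number considerably, but it does not fix the direction for a naphthalen-1-yl group. Given that, and since the step of a 9.4-fold lower number from compound 1 to compound 2 (0.97 log units; beyond the scatter) offers only a weak precedent, the expectation for compound 3 is a number close to that of compound 2, within a wide band. Compound 3 is estimated at 1500 nM, with a range from 500 nM to 5000 nM. This estimate corresponds to a 1.1-fold lower number from compound 2 to compound 3 (0.05 log units; within the scatter), a step expected to stay within or near the scatter.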

Compound 3, half-maximal effective concentration: 5600 nM
Compound 3: middle estimate off by 3.7-fold (0.57 log units), on the low side; measured number outside the range, above it.
By their numbers in this assay, from the lowest: compound 2; then compound 3; then compound 1.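

At the aromatic carbon that carries the exchange, naphthalen-1-yl does not behave like cyclohexylmethyl in this assay, the change being a 3.3-fold higher number from compound 2 to compound 3 (0.52 log units; beyond the scatter) for this pair of groups. Against 4-fluorophenoxy the same group gives a 2.9-fold lower number from compound 1 to compound 3 (0.46 log units; beyond the scatter) at this place, so all three groups are separated by steps beyond the scatter, with compound 3 lying between compound 2 and compound 1. Nothing measured here accounts for this order.

The three groups differ at once in ring type, size and attachment to the core, so the compounds shown do not separate these features. Also open, on these data alone, is whether a much smaller or charged group at this carbon, such as methoxy, a dimethylamino group or a carboxylic acid, would stay within the span set by compound 2 and compound 1.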